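The compounds below may be only part of what the source reports. "The series", "measured", "known", "first", "only" and "open" are said of these compounds alone.

Measured so far:
- compound 1, `CC(C)(N)CCC(=O)N[C@@H]1CCc2ccccc2N(Cc2ccc(-c3ccccc3-c3nn[nH]n3)cc2)C1=O`: 3 uM
- compound 2, `CCCNC(C)(C)CC(=O)N[C@@H]1CCc2ccccc2N(Cc2ccc(-c3ccccc3-c3nn[nH]n3)cc2)C1=O`: 50 uM

Both compounds share one core and differ only in the chain that hangs from the amide carbonyl. In a functional assay on cells (Pituitary gland cell) with growth hormone secretagogue receptor type 1 (Rattus norvegicus) as the target (on this read-out higher numbers stand for an effect only at larger amounts of compound and lower numbers for an effect already at smaller amounts), compound 1 gives 3 uM, and compound 2 gives 50 uM. Among the measured compounds shown here, the single step between them, a 17-fold higher number from compound 1 to compound 2 (1.22 log units; beyond the scatter), puts compound 2 at the higher of the two numbers.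

Compound 3, `NCC(=O)N[C@@H]1CCc2ccccc2N(Cc2ccc(-c3ccccc3-c3nn[nH]n3)cc2)C1=O`, carries the same core with the chain cut back: amino in place of 1-methyl-1-(propylamino)ethyl on a saturated chain carbon bound to a carbonyl carbon. This is a different kind of change from the one measured so far, since the carbon branch and the propyl on the nitrogen both leave at once and a bare amino remains. For the measured compounds named here, the only step that bears on it, from compound 1 to compound 2, shows that a change at this same place moved the number a long way, so a sizeable move is plausible here too; compound 3 keeps an unsubstituted amino, as compound 1 does, which is the one hint toward a lower number. The step is expected to be a 3.3-fold lower number from compound 2 to compound 3 (0.52 log units; beyond the scatter), with wide uncertainty. Compound 3 is estimated at 15 uM, between 3 uM and 100 uM.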

Compound 3, concentration for half-maximal effect: 9 uM
Compound 3: middle estimate off by 1.7-fold (0.22 log units), on the high side; low and high end bracket the measured number.
By their numbers in this assay, from the lowest: compound 1; then compound 3; then compound 2.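

In this assay, cutting the chain back to a bare amino gives a 5.6-fold lower number from compound 2 to compound 3 (0.74 log units; beyond the scatter), so a far smaller group recovers part of the ground lost with the 1-methyl-1-(propylamino)ethyl chain. Yet a 3.0-fold higher number from compound 1 to compound 3 (0.48 log units; beyond the scatter) shows that this amino group does not match the 2-amino-2-methylpropyl chain, so the number at this place on the saturated chain carbon does not simply follow chain size: compound 3, with the shortest chain, falls in the middle, and compound 1 and compound 3, which both keep an unsubstituted amino, stand lower than compound 2, which has the propyl on its nitrogen. Nothing available accounts for these differences in terms of mechanism.

The three compounds leave open whether the propyl on the nitrogen or the shape of the carbon chain matters more, since compound 2 and compound 3 differ in both at once. A methylamino group on the same chain, or a straight aminopropyl chain without the two methyl branches, would help to separate these two features.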